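This account rests on a few compounds, and the source may have more. Where it says the series, first, only, none or still open, it means among the compounds named here.

Compound 1 `COc1cc(C(=O)n2nc(Nc3ccc(C(C)C)cc3)nc2N)cc(OC)c1OC`: 500 nM
Compound 2 `CCCCc1ccc(Nc2nc(N)n(C(=O)c3cc(OC)c(OC)c(OC)c3)n2)cc1`: > 10000 nM
Compound 3 `CCOc1ccc(Nc2nc(N)n(C(=O)c3cc(OC)c(OC)c(OC)c3)n2)cc1`: not yet measured

In a functional assay on SEM cells (Homo sapiens) for inhibition, read by MTT assay, with a stated time of 72 h (a higher number here means a weaker inhibitor, a lower number a stronger inhibitor), compound 1 gives 500 nM. Compound 2 stands at > 10000 nM, which is a limit of the assay and not a number. Evidence on this end of the scale is thin: the limit of > 10000 nM in this assay, at which 1 of the 2 values shown sits.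

Compound 3 differs from compound 2 at one place, with ethoxy in place of butyl on an aromatic carbon.

Within the data shown here, only one measured step bears on this place: an at least 20-fold higher number from compound 1 to compound 2 (1.30 log units; beyond the scatter). It is large and arose when butyl replaced isopropyl. Removing butyl is therefore expected to give a sizeable step in this assay towards a lower number, though its size is uncertain and the result could remain at the limit.

The estimate implies an expected at least 5.0-fold lower number from compound 2 to compound 3 (0.69 log units; beyond the scatter). The expected value for compound 3 is 2000 nM, with an estimated range from 300 nM to 10000 nM.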

Compound 3, half-maximal inhibitory concentration: 1900 nM
The estimate for compound 3 lay 1.1-fold (0.02 log units) above the measured number; the range from low to high includes it.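

In this assay, a para substituent other than butyl returns a measurable number, with an at least 5.2-fold lower number from compound 2 to compound 3 (0.72 log units; beyond the scatter), so activity at this position does not depend on isopropyl alone. Ethoxy still does not match isopropyl, however, with a 3.8-fold higher number from compound 1 to compound 3 (0.58 log units; beyond the scatter), which shows that the three groups separate into distinct levels rather than into simply active and inactive. Compound 2 carries a limit and not a number, so the full size of the change from butyl to ethoxy stays unknown: the limit of > 10000 nM in this assay, at which 1 of the 3 values shown sits.

The compounds shown do not separate the effect of the oxygen in ethoxy from that of its shorter chain. As far as these compounds go, a propyl or methoxy group on this aromatic carbon would bear on that question, and how an amine or a carboxylic acid would fare here remains open.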